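A few compounds are considered here, and "the series" means these few. Any claim that something is new, unique, unknown or untested is made for them only; others in the source may bear on it.

In a functional assay on NCI-H157 cells (Homo sapiens) for antiproliferative activity, read by sulforhodamine B assay, with a stated time of 48 h, tested at 100 uM (a higher number here means more inhibition of growth at the concentration tested, a lower number less inhibition of growth), compound 1 `Fc1ccc(-c2nn3c(-c4ccncc4)nnc3s2)cc1Cl` gives 53.7%, while compound 2 `Fc1ccc(OCc2nn3c(-c4ccncc4)nnc3s2)cc1` gives 32%, the lower of the two numbers by a gap beyond the usual scatter. These two compounds differ in more than one place, so they offer no single step to reason from. Compound 3 `Oc1ccc(OCc2nn3c(-c4ccncc4)nnc3s2)cc1` has hydroxy in place of fluoro on an aromatic carbon, para to a large group: hydroxy in place of fluoro on an aromatic carbon. Only a small fall is expected in this assay, probably none beyond the scatter. The expected change is a number 4 percentage points lower from compound 2 to compound 3 (within the scatter). For compound 3, the estimated value is 28%, with an expected range of 10% to 47%.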

Compound 3, percent growth inhibition at one concentration: 63.7%
Compound 3: the middle estimate sits 35.7 percentage points below what was measured; the whole stated range lies below it.
By their numbers in this assay, from the lowest: compound 2; then compounds 1 and 3 (each within the scatter of the next).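

In this assay, hydroxy in place of fluoro on an aromatic carbon, para to a large group, gives a number 31.7 percentage points higher from compound 2 to compound 3 (beyond the scatter). Among the compounds shown here, this is the first step here that can be read at a single place, and it shows that the group at this position matters: exchanging one heavy atom for another changes growth inhibition by a large amount. Nothing at hand explains the size of this step. From the compounds shown here alone, whether a methoxy group or an amine at the same place would give a number like that of compound 3 remains open.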